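Piperidinyl replaces the furfuryl methylamino group

The source may report more compounds than this note shows. Statements on the series, on what has been measured and on what is new or still open speak of the compounds shown alone.

Of the compounds shown here, two of a shared core have been measured in an assay on cells for displacement of a labelled ligand from corticotropin-releasing factor receptor 1 (Homo sapiens), with a stated time of 100 min (a lower number here means a stronger inhibitor, a higher number a weaker inhibitor), so far. Compound 1 `Cc1cc(C)c(-n2c(Cl)cn3c(CN(C)Cc4ccccc4)c(C(F)(F)F)nc23)c(C)c1` gives 160 nM. Compound 2 `Cc1cc(C)c(-n2c(Cl)cn3c(CN(C)Cc4ccco4)c(C(F)(F)F)nc23)c(C)c1` gives 180 nM. The step between them, a 1.1-fold higher number from compound 1 to compound 2 (0.05 log units; within the scatter), is the only one available. On these two numbers compound 2 sits alongside compound 1, the pair being within the scatter of each other, so no ordering can be read from them.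

Compound 3 `Cc1cc(C)c(-n2c(Cl)cn3c(CN4CCCCC4)c(C(F)(F)F)nc23)c(C)c1` is not yet measured. It differs from compound 2 by piperidin-1-yl in place of ((furan-2-yl)methyl)(methyl)amino on a saturated chain carbon bound to an aromatic carbon. Going by the values given here, the single measured step concerns a swap of one aromatic group for another on the chain beyond the amine nitrogen, and it was within the scatter; it does not cover the removal of that chain altogether or the closing of the amine into piperidin-1-yl. The data therefore give no direct guide, and the expectation rests on the change being a larger one than the measured step. Compound 3 is expected to show a step of a 1.8-fold higher number from compound 2 to compound 3 (0.25 log units; within the scatter) in this assay, toward a somewhat higher number. The estimate for compound 3 is 320 nM, with a range from 100 nM to 1000 nM.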

Compound 3, inhibition constant: 1200 nM
Beside the measured number, compound 3's estimate is 3.8-fold (0.57 log units) below it; measured number above the stated range.
By their numbers in this assay, from the lowest: compounds 1 and 2 (each within the scatter of the next); then compound 3.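

In this assay, the (piperidin-1-yl)methyl group gives a clearly weaker inhibitor than either open-chain amine, with a 6.7-fold higher number from compound 2 to compound 3 (0.82 log units; beyond the scatter) and a 7.5-fold higher number from compound 1 to compound 3 (0.88 log units; beyond the scatter). Going by these compounds alone, the earlier swap of phenyl for furan-2-yl had left the number within the scatter, so this is the first sign that the group on this saturated chain carbon bound to an aromatic carbon can alter the result beyond the scatter. Both steps are modest and point the same way, whichever of the two aromatic groups compound 3 is compared with, and no measurement shown here accounts for the loss.

The compounds shown leave open whether the higher number goes with the loss of the aromatic ring on the chain, or with the closing of the amine into a piperidine ring, as both changes occur together in compound 3. A dimethylamino group, which keeps the open amine without the aromatic ring, and a 4-benzylpiperidin-1-yl group, which keeps a phenyl ring on the closed amine, would separate these two changes.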